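Compound 4: an aryl group enters at the saturated ring carbon

The compounds below may be only part of what the source reports. "The series", "measured", "known", "first", "only" and "open" are said of these compounds alone.

Compound 3 `CC1(c2ccccc2)CC(S(=O)(=O)c2ccc(F)cc2)=C(c2ccc(/C(N)=N\O)cc2)O1` holds the highest number among the three compounds measured in an ADME assay on HepG2 cells (Homo sapiens) for cytotoxicity, read by MTT assay, with a stated time of 72 h; a higher number here means that more compound is tolerated, a lower number that less compound is tolerated: compound 3 gives 68300 nM, while compound 1 `Cc1ccc(-c2ccc(C3(C)CC(S(=O)(=O)c4ccc(F)cc4)=C(c4ccc(/C(N)=N\O)cc4)O3)cc2)cc1` gives 13700 nM and compound 2 `CC1(c2ccc(Br)cc2)CC(S(=O)(=O)c2ccc(F)cc2)=C(c2ccc(/C(N)=N\O)cc2)O1` gives 19200 nM. Compound 4 `COc1ccc(C2(c3ccccc3)CC(S(=O)(=O)c3ccc(F)cc3)=C(c3ccc(/C(N)=N\O)cc3)O2)cc1` differs from compound 3 by 4-methoxyphenyl in place of methyl on a saturated ring carbon. For the measured compounds named here, no measured step changes this carbon; the nearest guidance is that adding groups elsewhere lowered the number, a 5.0-fold higher number from compound 1 to compound 3 (0.70 log units; beyond the scatter) and a 3.6-fold higher number from compound 2 to compound 3 (0.55 log units; beyond the scatter) being the reverse direction of such additions. A modest step downward is therefore expected in this assay for compound 4, a 2.7-fold lower number from compound 3 to compound 4 (0.44 log units; beyond the scatter), since the entering group is larger than anything added in compound 1 or compound 2. The estimate for compound 4 is 25000 nM, within 8000 nM to 70000 nM.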

Compound 4, half-maximal cytotoxic concentration: 29400 nM
The estimate for compound 4 lay 1.2-fold (0.07 log units) below the measured number, and the stated range covers the measured number.
By their numbers in this assay, from the lowest: compounds 1, 2 and 4 (each within the scatter of the next, the first and the last beyond it); then compound 3.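

In this assay the saturated ring carbon next to the ring oxygen proves sensitive to change: 4-methoxyphenyl in place of methyl gives a 2.3-fold lower number from compound 3 to compound 4 (0.37 log units; beyond the scatter) at this carbon. A lower number with a larger group is therefore no longer confined to the aromatic carbon changed in compound 1 and compound 2. No available evidence accounts for this step.

Open, on these data alone, is whether an ethyl group or an aminomethyl group at this carbon would lower the number as well. Also open, as far as these compounds go, is whether the methoxy of the 4-methoxyphenyl contributes to the step.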